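A Benzyl Group Replaces a Dimethoxyphenyl Ring

The source may report more compounds than this note shows. Statements on the series, on what has been measured and on what is new or still open speak of the compounds shown alone.

Measured so far in a functional assay on FM3A cells (Mus musculus) for inhibition, read by cell counting, with a stated time of 2 days; a lower number here means a stronger inhibitor, a higher number a weaker inhibitor:
Compound 1 `C=C(Br)C(=O)Nc1cccc(-c2cn3nc(-c4ccc(F)cc4)sc3n2)c1` gives 610 nM.
Compound 2 `C=C(Br)C(=O)Nc1cccc(-c2cn3nc(-c4ccc(OC)c(OC)c4)sc3n2)c1` gives 110 nM.

Among the measured compounds shown here, compound 2 has the lowest number of the two; the only other compound, compound 1, sits higher, and the step of a 5.5-fold lower number from compound 1 to compound 2 (0.74 log units; beyond the scatter) is beyond the scatter. Compound 3 `C=C(Br)C(=O)Nc1cccc(-c2cn3nc(Cc4ccc(OC)cc4)sc3n2)c1` has not yet been measured. It differs from compound 2 in one place: 4-methoxybenzyl in place of 3,4-dimethoxyphenyl on an aromatic carbon. For the measured compounds named here, no measured step makes this same kind of change, so the only guide is that exchanging the group at this carbon in compound 1 shifted the number by a 5.5-fold lower number from compound 1 to compound 2 (0.74 log units; beyond the scatter). That shows this position matters, but it gives no direction for a benzyl group carrying one methoxy. The expectation for compound 3 is therefore a modest rise in the number with a wide range, since a 5.5-fold lower number from compound 1 to compound 2 (0.74 log units; beyond the scatter) shows changes here can exceed the scatter. Compound 3 is estimated at 300 nM, between 80 nM and 1200 nM, an expected step of a 2.7-fold higher number from compound 2 to compound 3 (0.44 log units; beyond the scatter).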

Compound 3, half-maximal inhibitory concentration: 850 nM
For compound 3 the middle estimate is 2.8-fold (0.45 log units) below the measured one, within the range that was stated.
By their numbers in this assay, from the lowest: compound 2; then compounds 1 and 3 (each within the scatter of the next).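

Moving from the 3,4-dimethoxyphenyl group to 4-methoxybenzyl in this assay gives a 7.7-fold higher number from compound 2 to compound 3 (0.89 log units; beyond the scatter), so a ring carrying a methoxy group does not by itself preserve the low number at this aromatic carbon. Replacing 4-fluorophenyl with 4-methoxybenzyl gives a 1.4-fold higher number from compound 1 to compound 3 (0.14 log units; within the scatter), which leaves these two groups indistinguishable here, and only the 3,4-dimethoxyphenyl group of compound 2 stands apart from both. Nothing available explains the difference between compound 2 and compound 3.

On these data alone, the change from compound 2 to compound 3 both adds a carbon between the core and the ring and removes one methoxy group, so the share of each remains unknown. A 4-methoxyphenyl or a 3,4-dimethoxybenzyl group at this position would separate the two changes.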